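Chain extension from compound 2 to compound 3

This account rests on a few compounds, and the source may have more. Where it says the series, first, only, none or still open, it means among the compounds named here.

Measured so far in a functional assay on HepG2 cells (Homo sapiens) for antiproliferative activity; a lower number here means a stronger inhibitor, a higher number a weaker inhibitor:
compound 1 `CC(=O)OC[C@@H]1C=C[C@H](n2cc(F)c(N)nc2=O)O1`: > 100000 nM (a limit)
compound 2 `CCCC(=O)OC[C@@H]1C=C[C@H](n2cc(F)c(N)nc2=O)O1`: > 100000 nM (a limit)

Compound 2 has no numerical value, only the limit > 100000 nM. Both measured compounds stand at the limit of > 100000 nM in this assay, at which 2 of the 2 values shown sit, so neither gives a position within the range of the assay.

Compound 3 `CCCCC(=O)OC[C@@H]1C=C[C@H](n2cc(F)c(N)nc2=O)O1` differs from compound 2 by one change: methyl in place of hydrogen on a saturated chain carbon, three bonds along the chain from a carbonyl carbon.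

Within the data shown here, the only measured step that bears on this change is a step that the two limits leave unreadable from compound 1 to compound 2, which also lengthens the chain but gives no size to carry forward. No step beyond the scatter can be predicted from it, and compound 3 is expected to remain at the same limit in this assay. The expected step is a number no higher from compound 2 to compound 3 (the limit leaves the size open). For compound 3 the estimated value is 100000 nM, with an estimated range from 50000 nM to 200000 nM.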

Compound 3, half-maximal inhibitory concentration: > 100000 nM
Compound 3 ended at the assay's limit (the forecaster's own chance of this, stated with the estimate: 80%); the middle value lies on the limit itself.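

In this assay compound 3 gives > 100000 nM, which is a limit. No step can be read among compound 1, compound 2 and compound 3, as all three stay at the same limit: the limit of > 100000 nM in this assay, at which 3 of the 3 values shown sit.

The compounds shown leave open how far each lies beyond that limit, and whether any chain length gives a measurable value.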